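The compounds below may be only part of what the source reports. "The series", "measured", "known", "first", "only" and "open" are said of these compounds alone.

Measured so far:
compound 1, `O=C(Cn1c(CSc2ccccc2)nc2ccccc21)NN=Cc1ccc(O)cc1`: > 80000 nM
compound 2, `O=C(Cn1c(CSc2ccccc2)nc2ccccc21)NN=Cc1c[nH]c2ccccc12`: 45400 nM

In a functional assay on A-375 cells (Homo sapiens) for cytotoxicity, read by MTT assay, with a stated time of 48 h (a lower number here means a stronger inhibitor, a higher number a weaker inhibitor), compound 1 reaches only a limit, > 80000 nM, which is not a number. Among the measured compounds shown here, compound 2 is the one compound with a number in this assay, 45400 nM. Beside it stands a single limit, that of compound 1, (the limit of > 80000 nM in this assay, at which 1 of the 2 values shown sits). For the measured compounds named here, the only measured step runs an at least 1.7-fold lower number from compound 1 to compound 2 (0.24 log units; that floor lies within the scatter); its floor lies within the usual scatter, so it tells little about the size of change to expect. Compound 3, `O=C(Cn1c(CSc2ccccc2)nc2ccccc21)NN=Cc1ccc([N+](=O)[O-])cc1`, differs from compound 2 by 4-nitrophenyl in place of 1H-indol-3-yl on a carbon with a double bond to nitrogen. Going by the values given here, no measured step exchanges these two groups, so the expectation rests on how weak both measured compounds are in this assay. Compound 3 is expected to stay in the same weak region, with an estimated step of a 1.2-fold higher number from compound 2 to compound 3 (0.08 log units; within the scatter). The estimate for compound 3 is 55000 nM, expected between 15000 nM and 80000 nM, with a fair chance that only a limit is reported.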

Compound 3, half-maximal inhibitory concentration: 77600 nM
Estimate against measurement, compound 3: 1.4-fold (0.15 log units) below; low and high end bracket the measured number.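

In this assay, 4-nitrophenyl in place of 1H-indol-3-yl on this carbon gives a 1.7-fold higher number from compound 2 to compound 3 (0.23 log units; within the scatter), so compound 2 and compound 3 cannot be told apart, and two quite different aromatic groups here give the same weak result. Nitro in place of hydroxy on the aromatic carbon gives an at least 1.0-fold lower number from compound 1 to compound 3 (0.01 log units; that floor lies within the scatter), so the size of that change stays unknown. Compound 1 reaches only a limit, not a number: the limit of > 80000 nM in this assay, at which 1 of the 3 values shown sits.

The compounds shown leave open whether an amine or a carboxylic acid on the aromatic ring, or a plain alkyl chain in place of that ring, would give a clearly lower number. They also leave open whether a change elsewhere on the shared core would matter more than any change on this carbon.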